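Compound 1 and its mirror image

A few compounds are considered here, and "the series" means these few. Any claim that something is new, unique, unknown or untested is made for them only; others in the source may bear on it.

Compound 1 `Nc1ccn([C@@H]2S[C@H](CO)[C@H]2CO)c(=O)n1`: 54800 nM
Compound 2 `Cc1cn([C@H]2S[C@@H](CO)[C@@H]2CO)c(=O)[nH]c1=O`: > 100000 nM

Among the measured compounds shown here, in a functional assay on Vero cells (Chlorocebus sabaeus) for cytotoxicity (on this read-out higher numbers stand for weaker inhibition and lower numbers for stronger inhibition), compound 1 gives 54800 nM, the only actual number so far. Compound 2 shows > 100000 nM, which is a limit of the assay and not a number.

Compound 3 `Nc1ccn([C@H]2S[C@@H](CO)[C@@H]2CO)c(=O)n1` is the mirror image of compound 1: the two compounds have the same atoms and bonds and differ only in configuration as drawn: 3 of 3 stereo elements differ (all stereocentres are inverted: mirror images); a stereocentre at a saturated ring carbon is drawn R in compound 1 and S in compound 3; a stereocentre at a saturated ring carbon is drawn S in compound 1 and R in compound 3; a stereocentre at a saturated ring carbon is drawn R in compound 1 and S in compound 3. For the measured compounds named here, no measured step exists to guide the comparison, so only a modest shift toward weaker inhibition in this assay is expected, possibly none beyond the scatter. The expected change is a 1.5-fold higher number from compound 1 to compound 3 (0.16 log units; within the scatter). For compound 3 the estimated value is 80000 nM, with an expected range of 30000 nM to 200000 nM.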

Compound 3, half-maximal inhibitory concentration: > 100000 nM
Compound 3: only a limit was reported; the forecaster's own chance of this, stated with the estimate: 50%; middle value at least 1.2-fold (0.09 log units) away from the limit.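

In this assay compound 3 gives > 100000 nM, which is a limit of the assay and not a number. Inverting all the stereocentres gives an at least 1.8-fold higher number from compound 1 to compound 3 (0.26 log units; that floor lies within the scatter), so this result alone does not separate the mirror images. Among the compounds shown here, this is the first comparison here that tests handedness alone: the fact that compounds 1 and 3 differ only in the configuration as drawn.

Going by these compounds, the true size of the step stays open, with the reading capped: the limit of > 100000 nM in this assay, at which 2 of the 3 values shown sit. Also open, on these data alone, is how an amine or a carboxylic acid added to the shared core would change the reading in this assay.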